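Ethoxymethyl in Place of Chloro on the Shared Core

The compounds below may be only part of what the source reports. "The series", "measured", "known", "first", "only" and "open" are said of these compounds alone.

Compound 1 `COc1ccc(Cc2oc3c(Cl)cc(Cl)c(O)c3c2C)cc1` was tested in a functional assay for inhibition of Polyunsaturated fatty acid 5-lipoxygenase (Homo sapiens), in the absence of a further agent (a higher number here means a weaker inhibitor, a lower number a stronger inhibitor), where compound 1 gives 860 nM, the highest of the three numbers shown. In this assay compound 2 `CCCc1cc(F)c2oc(Cc3ccc(OC)cc3)c(C)c2c1O` gives 7 nM, and compound 3 `CCCc1cc(Cl)c2oc(Cc3ccc(Cl)cc3)c(C)c2c1O` gives 26 nM; both carry a propyl chain in place of the chloro group of compound 1, and both differ from compound 1 in more than one place. Compound 4 `CCOCc1cc(Cl)c2oc(Cc3ccc(OC)cc3)c(C)c2c1O` is not yet measured. It differs from compound 1 by ethoxymethyl in place of chloro on an aromatic carbon. Within the data shown here, no single-change step is available, so the expectation rests on what the values of compound 2 and compound 3 show. Compound 4 is expected to be a clearly stronger inhibitor, with an estimated step of a 22-fold lower number from compound 1 to compound 4 (1.33 log units; beyond the scatter). The estimate for compound 4 is 40 nM, within a range from 10 nM to 200 nM.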

Compound 4, half-maximal inhibitory concentration: 291 nM
Compound 4: the middle estimate sits 7.3-fold (0.86 log units) below what was measured, outside the stated range (above it).
By their numbers in this assay, from the lowest: compound 2; then compound 3; then compound 4; then compound 1.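

In this assay, among these compounds, the first single-change step at this position, on the aromatic carbon ortho to a hydroxy group, gives a 3.0-fold lower number from compound 1 to compound 4 (0.47 log units; beyond the scatter) and so marks ethoxymethyl in place of chloro as a modest gain. A chain holding an oxygen can therefore stand at this place without loss of inhibition. No measured property bears on this result, so its source stays unassigned. The compounds shown leave open how an amine or a carboxylic acid would compare at this position, and whether a longer ether chain would go further.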